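Swapping the aniline ring on a shared core

The source may hold more compounds than are shown below. What is called first, only, known or untested is meant among the compounds shown, and "the series" means these compounds.

Measured compounds:
compound 1 `CC(C)n1cnc2c(Nc3ccccc3)nc(NCOCc3ccc(C(=O)Nc4ccccc4N)cc3)nc21`, 34.3%
compound 2 `Cc1ccc(Nc2nc(Cl)nc3c2ncn3Cc2ccc(C(=O)Nc3ccccc3N)cc2)cc1`, 82.5%
compound 3 `Cc1ccc(Nc2nc(Cl)nc3c2ncn3Cc2ccc(/C=C/C(=O)Nc3ccccc3N)cc2)cc1`, 51.3%

In a functional assay on NCI-H460 cells (Homo sapiens) for antiproliferative activity, read by CCK-8 assay, with a stated time of 72 h, tested at 8 uM (a higher number here means a stronger effect of the compound at the concentration tested, a lower number a weaker effect), compound 3 stands second of the three, with compound 1 lower by a margin beyond the scatter and compound 2 higher, the difference being a number 31.2 percentage points lower from compound 2 to compound 3 (beyond the scatter). Compound 4 `Nc1ccccc1NC(=O)/C=C/c1ccc(Cn2cnc3c(Nc4cccc(OC(F)(F)F)c4)nc(Cl)nc32)cc1` differs from compound 3 in one place: 3-(trifluoromethoxy)phenyl in place of 4-methylphenyl on a nitrogen on an aromatic ring. Among the measured compounds shown here, no measured step touches this part of the molecule; the only step, a number 31.2 percentage points lower from compound 2 to compound 3 (beyond the scatter), concerns the linker carrying the (2-aminophenyl)carbamoyl group, so it gives no guide for the change to the nitrogen on the aromatic ring. Compound 4 is therefore expected to stay close to compound 3, with an estimated step of a number 1.3 percentage points lower from compound 3 to compound 4 (within the scatter). The estimate for compound 4 in this assay is 50%, ranging from 28% to 72%.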

Compound 4, a percentage reported as inhibition, at one concentration (the size of the read-out at that concentration, not a potency): 66.7%
Compound 4: the middle estimate sits 16.7 percentage points below what was measured; low and high end bracket the measured number.
By their numbers in this assay, from the lowest: compound 1; then compound 3; then compound 4; then compound 2.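

Changing the aniline ring is not neutral in this assay: 3-(trifluoromethoxy)phenyl in place of 4-methylphenyl gives a number 15.4 percentage points higher from compound 3 to compound 4 (beyond the scatter) with the ethenyl linker unchanged. This is the first step shown at this position, and it indicates that the ring on this nitrogen, not just the linker, affects the read-out. No measurement here explains the rise.

From the compounds shown here alone, whether the same swap would give a similar step in compound 2, which has no ethenyl linker, stays open. So does the effect of an amine or a carboxylic acid on this ring.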